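The source may report more compounds than this note shows. Statements on the series, on what has been measured and on what is new or still open speak of the compounds shown alone.

Measured in a functional assay on HCT-116 cells (Homo sapiens), read by MTT assay, with a stated time of 72 h; a higher number here means a weaker inhibitor, a lower number a stronger inhibitor:
- Compound 1 `Cc1ncnc2c1c(-c1ccoc1)cn2[C@@H]1O[C@H](CO)[C@@H](O)[C@H]1O`: > 20000 nM (a limit, not a number)
- Compound 2 `Nc1nc2c(c(-c3ccco3)cn2[C@@H]2O[C@H](CO)[C@@H](O)[C@H]2O)c(=O)[nH]1`: > 20000 nM (a limit, not a number)

Compound 2 stands at the limit of > 20000 nM in this assay, at which 2 of the 2 values shown sit, so no number is available for it. Compound 3 `Nc1nc2c(c(-c3cc4ccccc4o3)cn2[C@@H]2O[C@H](CO)[C@@H](O)[C@H]2O)c(=O)[nH]1` carries 1-benzofuran-2-yl in place of furan-2-yl on an aromatic carbon of the shared core: 1-benzofuran-2-yl in place of furan-2-yl on an aromatic carbon. Going by the values given here, no measured step shows the effect of such a change. The estimated step of a number no higher from compound 2 to compound 3 (the limit leaves the size open) is therefore expected to show no change beyond the scatter in this assay. For compound 3 the expected value is 20000 nM, with an estimated range of 5000 nM to 40000 nM.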

Compound 3, half-maximal inhibitory concentration: > 100000 nM
Compound 3 ended at the assay's limit; the forecaster's own chance of this, stated with the estimate: 70%; middle value at least 5.0-fold (0.69 log units) from the limit.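

In this assay compound 2 gives > 20000 nM as a limit. Compound 3 gives > 100000 nM as a limit too, so no step can be read between them. Going by these compounds, the effect of 1-benzofuran-2-yl in place of furan-2-yl on a numerical value remains open.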